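This account rests on a few compounds, and the source may have more. Where it says the series, first, only, none or still open, it means among the compounds named here.

Three measured compounds share one core and differ in the group that sits on a saturated chain carbon bound to an aromatic nitrogen: compound 1 `Fc1cccc(F)c1Cn1ccc2nc(-c3c(F)cccc3F)nc-2c1`, compound 2 `COc1ccccc1Cn1ccc2nc(-c3ccccc3)nc-2c1` and compound 3 `Fc1ccc(Cn2ccc3nc(-c4ccccc4)nc-3c2)cc1`. In an ADME assay on MDBK cells (Bos taurus) for cytotoxicity (on this read-out lower numbers stand for higher toxicity in this test and higher numbers for lower toxicity in this test), compound 1 gives > 100000 nM, which is a limit of the assay rather than a number. In this assay compound 2 likewise reaches only a limit, > 100000 nM. Compound 3 also stops at a limit in this assay, > 100000 nM. Compound 2 therefore stands at a limit, as do the other two values shown, and the limit of > 100000 nM in this assay, at which 3 of the 3 values shown sit, is the whole of the evidence.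

Compound 4 `Brc1cccc(Cn2ccc3nc(-c4ccccc4)nc-3c2)c1` is not yet measured. It differs from compound 2 in one place: 3-bromophenyl in place of 2-methoxyphenyl on a saturated chain carbon bound to an aromatic nitrogen. Among the measured compounds shown here, the one measured step that bears on this change, a step that the two limits leave unreadable from compound 2 to compound 3, swaps the same ring, yet its size cannot be read with both values at the limit. No guidance for a step in either direction exists, so no step beyond the scatter is expected in this assay from compound 2 to compound 4.

Compound 4 is accordingly expected to sit at or beyond the same limit, with an estimate of 150000 nM ranging from 60000 nM to 400000 nM. For compound 4 the expected step that the limit leaves unreadable from compound 2 to compound 4 is thus estimated as none beyond the scatter.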

Compound 4, half-maximal cytotoxic concentration: 85000 nM
Estimate against measurement, compound 4: 1.8-fold (0.25 log units) above; low and high end bracket the measured number.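

In this assay, among the compounds shown here, compound 4 gives 85000 nM, the first value in this set that is an actual number and not a limit, so with 3-bromophenyl on a saturated chain carbon bound to an aromatic nitrogen the read-out falls within the measurable range. Replacing 2-methoxyphenyl with 3-bromophenyl gives an at least 1.1-fold lower number from compound 2 to compound 4 (0.07 log units; that floor lies within the scatter), and replacing 4-fluorophenyl with 3-bromophenyl gives an at least 1.1-fold lower number from compound 3 to compound 4 (0.07 log units; that floor lies within the scatter); each is only a floor, so the true size of either step remains unknown and neither is shown to exceed the normal scatter of the test. Steps between compounds that both sit at the limit cannot be read, and the comparison sets one number against limits: the limit of > 100000 nM in this assay, at which 3 of the 4 values shown sit.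

The compounds shown leave open whether 3-bromophenyl truly differs from the other rings by more than the scatter, and whether the bromine or its place on the ring matters, as neither 4-bromophenyl nor 3-chlorophenyl appears among them. They also leave open how the read-out responds to a phenyl ring carrying an amine or a carboxylic acid on this carbon.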